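Two Methyls on the Pendant Ring: What to Expect of Compound 4

The source may hold more compounds than are shown below. What is called first, only, known or untested is meant among the compounds shown, and "the series" means these compounds.

Three compounds sharing one core differ only in the aromatic ring attached to it. Compound 1 `CCC1=C(O)c2c(oc(-c3cccc(C)c3)cc2=O)C(CC)(CC)C1=O` carries a 3-methylphenyl group and, in a functional assay on KBVIN cells (Homo sapiens) for antiproliferative activity, read by sulforhodamine B assay, with a stated time of 3 days (on this read-out lower numbers stand for an effect already at smaller amounts and higher numbers for an effect only at larger amounts of compound), compound 1 gives 3.69 uM. Compound 2 `CCC1=C(O)c2c(oc(-c3cccc(F)c3)cc2=O)C(CC)(CC)C1=O` carries a 3-fluorophenyl group, and in this assay compound 2 gives 3.09 uM. Compound 3 `CCC1=C(O)c2c(oc(-c3ccc(OC)cc3C)cc2=O)C(CC)(CC)C1=O` carries a 4-methoxy-2-methylphenyl group, and compound 3 gives 2.62 uM, the smallest of the three numbers; the step of a 1.4-fold lower number from compound 1 to compound 3 (0.15 log units; within the scatter) and the step of a 1.2-fold lower number from compound 2 to compound 3 (0.07 log units; within the scatter) are both within the usual scatter, so the three compounds cannot be told apart on these numbers.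

Compound 4 `CCC1=C(O)c2c(oc(-c3cc(C)cc(C)c3)cc2=O)C(CC)(CC)C1=O` has not yet been measured. It differs from compound 3 in one place: 3,5-dimethylphenyl in place of 4-methoxy-2-methylphenyl on an aromatic carbon. For the measured compounds named here, the steps that bear on this change are those between the measured pendant rings, a 1.2-fold lower number from compound 1 to compound 2 (0.08 log units; within the scatter) and a 1.4-fold lower number from compound 1 to compound 3 (0.15 log units; within the scatter), and neither moved the number beyond the scatter. Every change of this ring so far has left the read-out essentially unchanged, so no step beyond the scatter is expected here either.

The expected step is a 1.2-fold higher number from compound 3 to compound 4 (0.09 log units; within the scatter). Compound 4 is therefore estimated at 3.2 uM, with a plausible range from 1.5 uM to 7 uM.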

Compound 4, concentration for half-maximal effect: 0.45 uM
Beside the measured number, compound 4's estimate is 7.1-fold (0.85 log units) above it; measured number below the stated range.
By their numbers in this assay, from the lowest: compound 4; then compounds 3, 2 and 1 (each within the scatter of the next).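

In this assay, for the compounds shown here, this position on the ring turns out not to be indifferent after all: placing a methyl in place of hydrogen on an aromatic carbon gives an 8.2-fold lower number from compound 1 to compound 4 (0.91 log units; beyond the scatter) and is the first change here to lie beyond the scatter. The other two steps, a 5.8-fold lower number from compound 3 to compound 4 (0.77 log units; beyond the scatter) and a 6.9-fold lower number from compound 2 to compound 4 (0.84 log units; beyond the scatter), are also beyond the scatter, so compound 4 stands apart from all three earlier compounds, which could not be told apart from one another. Having two groups on the pendant ring is not enough by itself, as compound 3 with its 4-methoxy-2-methylphenyl group goes against that idea and stays with compounds 1 and 2, so what sets compound 4 apart is tied to the 3,5-dimethylphenyl group as a whole, and nothing available here explains how that group produces this difference.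

Going by these compounds, it remains open whether the low number holds when the two methyls of the 3,5-dimethylphenyl group give way to ethyl groups, methoxy groups or chlorine atoms. Also open, on these data alone, is what an amine or a carboxylic acid on this ring would do to the number.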